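A few compounds are considered here, and "the series" means these few. Any claim that something is new, unique, unknown or untested is made for them only; others in the source may bear on it.

Working notes on the series.

Among the measured compounds shown here, compound 2 `Fc1ccccc1COc1ccccc1/C=C/C(/C=C/c1ccccn1)=N/Oc1ncnc2cc(Cl)ccc12` gives the highest of the three numbers measured so far: in a functional assay on SMMC-7721 cells (Homo sapiens) for inhibition, read by MTT assay, with a stated time of 72 h, tested at 1 uM (a higher number here means a stronger effect of the compound at the concentration tested, a lower number a weaker effect), compound 2 gives 94.2%. Its nearest neighbour is compound 3 `Fc1ccccc1COc1ccc(/C=C/C(/C=C/c2ccccn2)=N/Oc2ncnc3cc(Cl)ccc23)cc1`, which in this assay gives 81.1%; furthest is compound 1 `Clc1ccc2c(O/N=C(/C=C/c3ccc(OCc4ccccc4Cl)cc3)\C=C\c3ccccn3)ncnc2c1`, which in this assay gives 18.1%. Both gaps from compound 2 lie beyond the scatter.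

The step under consideration leads to compound 4 `Clc1ccc(COc2ccccc2/C=C/C(/C=C/c2ccccn2)=N/Oc2ncnc3cc(Cl)ccc23)cc1`, not yet measured. The change is 4-chlorophenyl in place of 2-fluorophenyl on a saturated chain carbon bound to an oxygen on an aromatic ring.

For the measured compounds named here, the only measured step that bears on it is a number 63 percentage points higher from compound 1 to compound 3 (beyond the scatter), where replacing chloro with fluoro on the benzyl ring raised the read-out by a large margin. Compound 4 goes the other way, fluoro to chloro, though with the chloro now carried at a different place on the benzyl ring, so the comparison is only indirect. On that basis a drop beyond the scatter from compound 2 is expected, but since compound 2 already sits very high and the change is not the exact reverse of the measured one, the drop is estimated at a number 39.2 percentage points lower from compound 2 to compound 4 (beyond the scatter). That is less than the full size of the measured step just described. Compound 4 is therefore expected to give about 55% in this assay, with a plausible range from 20% to 90%.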

Compound 4, a percentage reported as inhibition, at one concentration (the size of the read-out at that concentration, not a potency): 94%
Compound 4: the middle estimate sits 39 percentage points below what was measured; measured number above the stated range.
By their numbers in this assay, from the lowest: compound 1; then compound 3; then compounds 4 and 2 (each within the scatter of the next).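

The change of 2-fluorophenyl to 4-chlorophenyl, on a saturated chain carbon bound to an oxygen on an aromatic ring, leaves the read-out in this assay unmoved: a number 0.2 percentage points lower from compound 2 to compound 4 (within the scatter). This position on the compound 2 scaffold therefore accepts a chlorinated phenyl as well as a fluorinated one, and the large step of a number 63 percentage points higher from compound 1 to compound 3 (beyond the scatter), which belongs to a different parent and a different pair of groups, gives no general rule that fluoro outperforms chloro on this ring. No measurement in hand bears on why the two groups read alike.

The compounds shown leave open whether this tolerance extends to groups unlike either halogenated phenyl at the same place, such as an unsubstituted phenyl or a chain carrying an amine. They also leave open whether compound 2 and compound 4 would still read alike at a lower concentration, since one concentration gives the size of the read-out and not a potency, and both compounds stand high in this assay.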